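This account rests on a few compounds, and the source may have more. Where it says the series, first, only, none or still open, it means among the compounds named here.

In a functional assay on the whole organism (artery, strain albino) with Rattus norvegicus as the target, with a stated time of 600 min, at a dose of 10 mg/kg by the oral route (a lower number here means less inhibition, a higher number more inhibition at the dose given (going by the name of the read-out)), three compounds have been measured:

compound 1 `CC1=C(C(=O)Nc2ccc(F)cc2)C(c2ccc([N+](=O)[O-])cc2)N=C(SCc2ccccc2)N1`: 32.3%
compound 2 `CC1=C(C(=O)Nc2ccc(F)cc2)C(c2ccc([N+](=O)[O-])cc2)N=C(SCc2ccc(F)cc2)N1`: 25.6%
compound 3 `CC1=C(C(=O)Nc2ccc(Br)cc2)C(c2ccc(Cl)cc2Cl)N=C(SCc2ccccc2)N1`: 17.4%

Compound 3 stands lowest of the three. Its nearest neighbour is compound 2, whose number lies higher by an amount within the scatter, while compound 1 lies higher by an amount beyond the scatter. Compound 4 `CC1=C(C(=O)Nc2ccc(Br)cc2)C(c2ccc(Cl)cc2Cl)N=C(SCc2ccc(Cl)cc2)N1` has not yet been measured. It differs from compound 3 in a single place: chloro in place of hydrogen on an aromatic carbon. For the measured compounds named here, one measured step bears on this change. From compound 1 to compound 2 a fluoro replaced a hydrogen on the ring of the benzyl group, the same ring that takes the chloro in compound 4, and a number 6.7 percentage points lower from compound 1 to compound 2 (within the scatter). Because a number 6.7 percentage points lower from compound 1 to compound 2 (within the scatter) stayed within the scatter, a halogen entering the same ring of compound 3 is expected to move the number little, with at most a slight lean downward in the same direction as that step. Compound 4 is expected to give 14% in this assay, within a range of 4% to 26%. The estimated step is a number 3.4 percentage points lower from compound 3 to compound 4 (within the scatter), which lies within the scatter.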

Compound 4, a percentage reported as inhibition, in the whole organism at one dose (the size of the read-out at that dose, not a potency): 30.3%
Compound 4: middle estimate off by 16.3 percentage points, on the low side; the whole stated range lies below it.
By their numbers in this assay, from the lowest: compounds 3, 2, 4 and 1 (each within the scatter of the next, the first and the last beyond it).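

The benzyl position can register a change larger than the scatter: in this assay going from benzylsulfanyl to (4-chlorobenzyl)sulfanyl gives a number 12.9 percentage points higher from compound 3 to compound 4 (beyond the scatter). For the compounds shown here, the only earlier halogen step at this ring, a number 6.7 percentage points lower from compound 1 to compound 2 (within the scatter), stayed within the scatter and pointed downward, so that step did not carry over to this pair, and a halogen at this place cannot be treated as a change that leaves the number alone or lowers it throughout the series. Nothing measured here accounts for the rise or for the difference between the two steps.

The two pairs differ in the entering halogen, chloro against fluoro, and also in the groups carried elsewhere on the shared core, and the compounds shown do not separate these two differences. Going by these compounds, how a methoxy group or an amine at the same place on the benzyl ring would read also remains open, as does the effect of a longer chain in place of the benzyl group.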